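Adding one methyl to an acetyl group at the clearance limit

The source may hold more compounds than are shown below. What is called first, only, known or untested is meant among the compounds shown, and "the series" means these compounds.

Compound 1 `CC[C@@H]1c2cc(Cl)ccc2C(=O)N1c1cncc2c1CCC[C@H]2NC(C)=O` and compound 2 `CC(=O)N[C@@H]1CCCc2c1cncc2N1C(=O)c2ccc(Cl)cc2[C@H]1C` share a core. In an ADME assay on microsomes from liver (Homo sapiens) for metabolic stability, read by LC-MS, using NADPH, with stated times of 10 min and 30 min (on this read-out higher numbers stand for fast clearance and lower numbers for slow clearance), compound 1 gives < 3.5 mL/min/kg, which is a limit and not a number. Compound 2 gives < 3.5 mL/min/kg, which is also a limit. Both compounds therefore rest on (the limit of < 3.5 mL/min/kg in this assay, at which 2 of the 2 values shown sit), so compound 2 has no exact clearance to start from.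

Compound 3 `CCC(=O)N[C@@H]1CCCc2c1cncc2N1C(=O)c2ccc(Cl)cc2[C@H]1C` differs from compound 2 by methyl in place of hydrogen on a saturated chain carbon bound to a carbonyl carbon, which turns acetyl into propanoyl. Among the compounds with values here, the only measured step is a step that the two limits leave unreadable from compound 1 to compound 2. It concerns a different methyl and offers no size to carry over, so nothing measured points to a real shift. In this assay the expected result is an at least 1.1-fold higher number from compound 2 to compound 3 (0.05 log units; that floor lies within the scatter), with nothing beyond the scatter anticipated. Compound 3 is estimated at 4 mL/min/kg, with an expected range of 2.5 mL/min/kg to 8 mL/min/kg.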

Compound 3, clearance: < 3.5 mL/min/kg
Compound 3 ended at the assay's limit (the forecaster's own chance of this, stated with the estimate: 55%); middle value at least 1.1-fold (0.05 log units) away from the limit.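

Compound 2 and compound 3 both give a limit and not a number, so no step between them can be read, and the same holds for compound 1: the limit of < 3.5 mL/min/kg in this assay, at which 3 of the 3 values shown sit.

The compounds shown leave open whether the change from acetyl to propanoyl alters clearance at all in this assay.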